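The compounds below may be only part of what the source reports. "The series", "measured", "known", "first", "only" and "open" are said of these compounds alone.

Measured so far in a functional assay on TK-10 cells (Homo sapiens) for inhibition; on this read-out higher numbers stand for weaker inhibition of growth and lower numbers for stronger inhibition of growth:
compound 1, `COc1cc(/C=C/C(=O)c2cccc(-n3cc(-c4ccc(Cl)cc4)[nH]c3=O)c2)ccc1O`, gives 4670 nM
compound 2, `COc1cc(/C=C/C(=O)c2cccc(-n3cc(-c4ccccc4)[nH]c3=O)c2)ccc1O`, gives 5290 nM
compound 3, `COc1ccc(-c2cn(-c3cccc(C(=O)/C=C/c4cc(OC)c(OC)c(OC)c4)c3)c(=O)[nH]2)cc1`, gives 3040 nM

Compound 1 stands second highest of the three numbers in this assay; its nearest neighbour is compound 2 and its furthest is compound 3, and both gaps lie within the scatter, so none of the three is set apart from the others. Among the compounds with values here, the only measured step with a single change, a 1.1-fold higher number from compound 1 to compound 2 (0.05 log units; within the scatter), concerns hydrogen in place of chloro on an aromatic carbon and moves nothing beyond the scatter.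

Compound 4, `O=C(/C=C/c1cccc(O)c1)c1cccc(-n2cc(-c3ccc(Cl)cc3)[nH]c2=O)c1`, is not yet measured. It differs from compound 1 as 3-hydroxyphenyl in place of 4-hydroxy-3-methoxyphenyl on a double-bonded chain carbon bound to a double-bonded chain carbon. Within the data shown here, no measured step touches this part of the shared core: compound 3 carries a different group at the same place but also differs elsewhere, so its value can only be read side by side with that of compound 1, and the two sit within the scatter. The step on record gives no guide to this change either. On that basis no step beyond the scatter is expected in this assay, and the estimate stays close to compound 1 with a wide range. Compound 4 is therefore expected to give 5500 nM in this assay, with a range from 2500 nM to 12000 nM. The expected step is a 1.2-fold higher number from compound 1 to compound 4 (0.07 log units; within the scatter).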

Compound 4, concentration for 50% growth inhibition: 2830 nM
The estimate for compound 4 lay 1.9-fold (0.29 log units) above the measured number; measured number inside the range.
By their numbers in this assay, from the lowest: compounds 4, 3, 1 and 2 (each within the scatter of the next).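

In this assay, within the data shown here, 3-hydroxyphenyl in place of 4-hydroxy-3-methoxyphenyl on a double-bonded chain carbon bound to a double-bonded chain carbon gives a 1.7-fold lower number from compound 1 to compound 4 (0.22 log units; within the scatter), the first step read at this part of the shared core. This place therefore takes this exchange of one hydroxy-bearing phenyl group for another without a shift beyond the scatter, which the side-by-side reading of compound 3 could not show. Nothing available accounts for the size of this step.

Still open, on these data alone, is whether a carboxylic acid or an amine carried on the phenyl group at this place would shift the number beyond the scatter. Also open, as far as these compounds go, is whether the same exchange reads alike on the core of compound 2, which has hydrogen in place of chloro.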